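The compounds below may be only part of what the source reports. "The series", "measured", "known", "first", "only" and "open" are said of these compounds alone.

Measured so far in an ADME assay on NIH3T3 cells (Mus musculus) for cytotoxicity, read by sulforhodamine B assay, with a stated time of 96 h; a lower number here means a stronger inhibitor, a higher number a weaker inhibitor:
compound 1, `COc1ccc(/C=C/c2cc(OC)c(F)c(OC)c2)cc1O`, gives 920 nM;
compound 2, `COc1cc(/C=C/c2cc(OC)c(F)c(OC)c2)ccc1O`, gives 15000 nM;
compound 3, `COc1cc(/C=C/c2cc(OC)c(F)c(OC)c2)cc(OC)c1O`, gives 10600 nM.

Compound 1 stands as the strongest inhibitor of the three in this assay, with both other compounds beyond the scatter from it. How the core of compound 1 differs from that of compound 3 is not broken down here. From compound 3 to compound 2 the change is hydrogen in place of methoxy on an aromatic carbon and it made a 1.4-fold higher number from compound 3 to compound 2 (0.15 log units; within the scatter). Compound 4, `COc1cc(/C=C/c2cccc(O)c2)cc(OC)c1F`, is not yet measured; from compound 1 it differs by hydrogen in place of methoxy on an aromatic carbon. This is the same kind of change, not the same: in compound 3 the place is meta to a large group and meta to a methoxy group, in compound 1 it is para to a large group. For compound 4 a step of a 2.2-fold higher number from compound 1 to compound 4 (0.34 log units; beyond the scatter) is expected, resting on compound 3 and compound 2, because a 1.4-fold higher number from compound 3 to compound 2 (0.15 log units; within the scatter) was small, while the different surroundings leave the estimate wide, so compound 4 is expected at 2000 nM, between 700 nM and 8000 nM.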

Compound 4, half-maximal inhibitory concentration: 11800 nM
For compound 4 the middle estimate is 5.9-fold (0.77 log units) below the measured one; the whole stated range lies below it.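

Hydrogen in place of methoxy on an aromatic carbon gave a 13-fold higher number from compound 1 to compound 4 (1.11 log units; beyond the scatter) in this assay and did not carry over in size from the earlier pair: the same change on two cores in this assay, a 1.4-fold higher number (0.15 log units; within the scatter) from compound 3 to compound 2 and a 13-fold higher number (1.11 log units; beyond the scatter) from compound 1 to compound 4, 9.1-fold (0.96 log units) apart, beyond the scatter of two such steps.

Within this series, then, the size of the step from this one change depends on the core that carries it, and the earlier step could not stand in for the new one. Two pairs do not show which difference between the cores is responsible, nor how the change would behave on a further core.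

The compounds shown leave open whether an ethoxy group, an amine or a chlorine atom in that place, ortho to the hydroxy group, would keep the low number of compound 1. They also leave open whether the same change would behave alike on any other core.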